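Methyl ester to acid: compound 2 toward compound 4

A few compounds are considered here, and "the series" means these few. Any claim that something is new, unique, unknown or untested is made for them only; others in the source may bear on it.

Three measured compounds share one core and differ only in the chain on the aromatic nitrogen. Compound 1 `COC(=O)c1c(F)cccc1-c1ccc(CCc2ncc(CC(C)(C)C)n2Cc2ccc(C(=O)O)cc2)cc1` carries 4-carboxyphenyl there, and in an assay on cells for agonist activity at Bombesin receptor subtype-3 (Homo sapiens), read by HTRF and inositol phosphate accumulation, with a stated time of 1 h (on this read-out lower numbers stand for an effect already at smaller amounts and higher numbers for an effect only at larger amounts of compound), compound 1 gives 3 nM. Compound 2 `COC(=O)c1c(F)cccc1-c1ccc(CCc2ncc(CC(C)(C)C)n2CCO)cc1` carries hydroxymethyl, and in this assay compound 2 gives 21 nM. Compound 3 `COC(=O)c1c(F)cccc1-c1ccc(CCc2ncc(CC(C)(C)C)n2CCNS(C)(=O)=O)cc1` carries (methanesulfonamido)methyl, and in this assay compound 3 gives 11 nM. Compound 2 stands at the highest number of the three: the step of a 7.0-fold higher number from compound 1 to compound 2 (0.85 log units; beyond the scatter) lies beyond the scatter, whereas the step of a 1.9-fold lower number from compound 2 to compound 3 (0.28 log units; within the scatter) stays within it, so compound 2 and compound 3 cannot be ordered against each other.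

Compound 4 `CC(C)(C)Cc1cnc(CCc2ccc(-c3cccc(F)c3C(=O)O)cc2)n1CCO` keeps the hydroxymethyl chain of compound 2 and changes only the oxygen next to a carbonyl group: hydrogen in place of methyl on an oxygen next to a carbonyl group. Among the compounds with values here, no measured step touches that oxygen; a 7.0-fold higher number from compound 1 to compound 2 (0.85 log units; beyond the scatter), a 3.7-fold higher number from compound 1 to compound 3 (0.56 log units; beyond the scatter) and a 1.9-fold lower number from compound 2 to compound 3 (0.28 log units; within the scatter) all concern the saturated chain carbon bound to the aromatic nitrogen, and the methoxycarbonyl is unchanged in compounds 1, 2 and 3. Within the data shown here, the step from compound 2 to compound 4 therefore has no precedent in this set. A step of a 1.2-fold higher number from compound 2 to compound 4 (0.08 log units; within the scatter) is expected, not beyond the scatter, with a wide allowance for the untested change. Compound 4 is estimated at 25 nM in this assay, within a range from 8 nM to 80 nM.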

Compound 4, half-maximal effective concentration: 3 nM
The estimate for compound 4 lay 8.3-fold (0.92 log units) above the measured number, outside the stated range (below it).
By their numbers in this assay, from the lowest: compounds 1 and 4 (each within the scatter of the next); then compounds 3 and 2 (each within the scatter of the next).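

The oxygen next to a carbonyl group is not a silent position in this series: methoxycarbonyl to carboxy gives a 7.0-fold lower number from compound 2 to compound 4 (0.85 log units; beyond the scatter) in this assay, with the chain on the aromatic nitrogen held as hydroxymethyl. Until now, all of the listed variation lay in that chain, where a 7.0-fold higher number from compound 1 to compound 2 (0.85 log units; beyond the scatter) accompanied the loss of 4-carboxyphenyl; the new step shows that a change at the far carbonyl, involving the loss of only one methyl group, can also move the number beyond the scatter. The compounds shown offer no measured explanation for this step.

This reading rests on a single pair, so it holds only for the hydroxymethyl chain. From the compounds shown here alone, whether the same hydrogen-for-methyl change moves the number in the same way with the 4-carboxyphenyl of compound 1 or the (methanesulfonamido)methyl of compound 3 remains open, as does the response at this carbonyl to an ethyl ester or a primary amide.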